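Carbamate Ester Variation on a Shared Cyclohexyl Ether Core

The source may report more compounds than this note shows. Statements on the series, on what has been measured and on what is new or still open speak of the compounds shown alone.

Measured compounds:
Compound 1, `CC(C)(C)OC(=O)N1CCC(O[C@H]2CC[C@H](Oc3ccc(S(C)(=O)=O)c(F)c3)CC2)CC1`, gives 167 nM in a functional assay on isolated protein for agonist activity at Glucose-dependent insulinotropic receptor (Rattus norvegicus), read by HTRF and cAMP accumulation; a higher number here means that more compound is needed for the effect, a lower number that less compound is needed.
Compound 2, `CC1(OC(=O)N2CCC(O[C@H]3CC[C@H](Oc4cnc(S(C)(=O)=O)cn4)CC3)CC2)CC1`, gives 138 nM in this assay.

Compound 2 holds the lower of the two numbers, but its nearest neighbour, compound 1, lies within the usual scatter of it, so the two cannot be told apart on these data. Compound 3, `CS(=O)(=O)c1cnc(O[C@H]2CC[C@H](OC3CCN(C(=O)OC4CCOC4)CC3)CC2)cn1`, has not been measured in this assay. It differs from compound 2 in one place: oxolan-3-yl in place of 1-methylcyclopropyl on an oxygen next to a carbonyl group. For the measured compounds named here, no step between measured compounds covers a change of this kind, so only the two measured values, both close together, give any footing. A modest move toward a higher number is expected for compound 3, with the step from a 2.2-fold higher number from compound 2 to compound 3 (0.34 log units; beyond the scatter) judged to sit near the edge of the scatter. Compound 3 is therefore estimated at 300 nM, within a range of 120 nM to 800 nM.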

Compound 3, half-maximal effective concentration: 1500 nM
Estimate against measurement, compound 3: 5.0-fold (0.70 log units) below; measured number outside the range, above it.
By their numbers in this assay, from the lowest: compounds 2 and 1 (each within the scatter of the next); then compound 3.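

In this assay, the change from 1-methylcyclopropyl to oxolan-3-yl on an oxygen next to a carbonyl group gives an 11-fold higher number from compound 2 to compound 3 (1.04 log units; beyond the scatter) and is a large step beyond the scatter. For the compounds shown here, this is the first reading of a single change at this position, and it shows that the group here is not interchangeable: the earlier pair differed in more than one place and could not show this. The entering group adds one heavy atom, a ring oxygen and one hydrogen-bond acceptor, but nothing measured here accounts for the size of the step.

The compounds shown do not separate the ring oxygen from the larger ring, which cyclopentyl at this position would address. On these data alone, whether the same step holds on the core of compound 1 also stays open.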